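Lengthening the tert-butyl group by one carbon

The source may hold more compounds than are shown below. What is called first, only, known or untested is meant among the compounds shown, and "the series" means these compounds.

Two compounds with a shared core and differing alkyl groups on the double-bonded nitrogen have been tested in a functional assay on the whole organism (blood, strain Wistar-Okamoto) with Rattus norvegicus as the target, with a stated time of 5 days; on this read-out higher numbers stand for an effect only at larger amounts of compound and lower numbers for an effect already at smaller amounts. Compound 1 `CC(C)CC(C)/N=C(\NC#N)Nc1ccncc1` gives 35 mg/kg in this assay. For the measured compounds named here, compound 2 `CC(C)(C)/N=C(\NC#N)Nc1ccncc1` gives 2.5 mg/kg in this assay, the lowest of the two numbers, and the only step measured so far, a 14-fold lower number from compound 1 to compound 2 (1.15 log units; beyond the scatter), is a large one beyond the scatter.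

Compound 3 `CCC(C)(C)/N=C(\NC#N)Nc1ccncc1` has not yet been measured. It differs from compound 2 in one place: methyl in place of hydrogen on a saturated chain carbon, two bonds along the chain from a double-bonded nitrogen. Going by the values given here, the only measured step, from compound 1 to compound 2, exchanged one whole alkyl group for another and therefore bears on this change only loosely; no measured pair shows what a single added methyl on the tert-butyl group does here. The change is small, so the expected step of a 1.2-fold higher number from compound 2 to compound 3 (0.08 log units; within the scatter) is estimated to fall within the usual scatter, with no clear direction. Compound 3 is therefore expected to give about 3 mg/kg in this assay, most likely between 1 mg/kg and 10 mg/kg.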

Compound 3, minimum effective dose: 2.5 mg/kg
For compound 3 the middle estimate is 1.2-fold (0.08 log units) above the measured one; the range from low to high includes it.
By their numbers in this assay, from the lowest: compounds 2 and 3 (each within the scatter of the next); then compound 1.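

Adding a methyl to tert-butyl, which gives 1,1-dimethylpropyl, leaves the read-out in this assay unmoved: the step shows no change at the digits printed from compound 2 to compound 3 (within the scatter) and so gives no sign that this saturated chain carbon, two bonds along the chain from a double-bonded nitrogen, is sensitive to this particular addition. The low number is also not unique to tert-butyl, since exchanging 1,3-dimethylbutyl for 1,1-dimethylpropyl gives a 14-fold lower number from compound 1 to compound 3 (1.15 log units; beyond the scatter) and thus a step of the same printed size as the one seen earlier with tert-butyl. No measurement here explains why the added methyl leaves the number in place.

As far as these compounds go, whether this carbon would tolerate a longer chain, a hydroxyl group or an amine in the same way stays open, as a single added methyl says little about larger groups or groups containing oxygen or nitrogen. It also remains unclear which feature of 1,3-dimethylbutyl goes with the higher number, since that group differs from both tert-butyl and 1,1-dimethylpropyl as a whole and not by a single added methyl.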